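The compounds below may be only part of what the source reports. "The series", "measured", "known", "first", "only" and "open" are said of these compounds alone.

Measured compounds in a functional assay on MCF7 cells (Homo sapiens) for antiproliferative activity, read by MTT assay, with a stated time of 72 h; a higher number here means a weaker inhibitor, a lower number a stronger inhibitor:
compound 1 `O=C1NC(=S)S/C1=C\C1=Cc2ccccc2OC1` gives 68700 nM
compound 2 `O=C1NC(=O)/C(=C/C2=Cc3ccccc3OC2)N1` gives 8100 nM
compound 3 `CN1C(=O)S/C(=C\C2=Cc3ccccc3OC2)C1=O` gives only a limit, > 100000 nM

Of the two plain numbers in this assay, compound 1 holds the higher one, and compound 2 stands at a lower number, a gap beyond the usual scatter. For compound 3 this assay reports a limit rather than a number (the limit of > 100000 nM in this assay, at which 1 of the 3 values shown sits). Compound 4 `O=C(O)CN1C(=O)/C(=C/C2=Cc3ccccc3OC2)SC1=S` differs from compound 1 by carboxymethyl in place of hydrogen on an amide-type nitrogen in a ring. Among the compounds with values here, no measured pair shows this change, so the step is an expectation only: from a 1.0-fold higher number from compound 1 to compound 4 (0.01 log units; within the scatter) no step beyond the scatter is expected, with a wide spread on either side. Compound 4 is therefore estimated at 70000 nM in this assay, between 20000 nM and 250000 nM.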

Compound 4, half-maximal inhibitory concentration: > 100000 nM
Compound 4: a limit, no number; the forecaster's own chance of this, stated with the estimate: 35%; middle value at least 1.4-fold (0.15 log units) from the limit.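

In this assay, carboxymethyl in place of hydrogen on the amide-type nitrogen gives an at least 1.4-fold higher number from compound 1 to compound 4 (0.16 log units; that floor lies within the scatter). Compound 4 gives only a limit, > 100000 nM, so the change yields a floor for the step rather than its size, and that floor does not separate compound 4 from compound 1. The same limit recurs in this short series: the limit of > 100000 nM in this assay, at which 2 of the 4 values shown sit.

The compounds shown leave open the true size of this step. They also leave open how an ethyl group or a longer chain ending in an amine would read on this nitrogen.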